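Shrinking the Amide Ring of Compound 1

The source may report more compounds than this note shows. Statements on the series, on what has been measured and on what is new or still open speak of the compounds shown alone.

compound 1 `CCN(CC)S(=O)(=O)c1ccc(S(=O)(=O)N2CCC[C@@H](C(=O)N3CCC(OC)CC3)C2)cc1`: 1420 nM
compound 2 `O=C([C@@H]1CCCN(S(=O)(=O)c2ccc(S(=O)(=O)C3CC3)cc2)C1)N1CCC(F)(F)CC1`: 129 nM

Both compounds were tested in a functional assay on BXPC-3 cells (Homo sapiens) for inhibition, read by MTT assay, with a stated time of 7 days; on this read-out higher numbers stand for weaker inhibition and lower numbers for stronger inhibition. Compound 1 gives 1420 nM, the higher of the two numbers and so the weaker inhibitor here; compound 2 gives 129 nM, a lower number well beyond the scatter. Compound 3 `CCN(CC)S(=O)(=O)c1ccc(S(=O)(=O)N2CCC[C@@H](C(=O)N3CC[C@@H](OC)C3)C2)cc1` has not been measured. It differs from compound 1 in one place: 3-methoxypyrrolidin-1-yl in place of 4-methoxypiperidin-1-yl on a carbonyl carbon. Going by the values given here, no measured pair shows this change, so there is no step to lean on, and the change is modest in size. The expected step is a 1.1-fold higher number from compound 1 to compound 3 (0.02 log units; within the scatter), within the scatter. Compound 3 is estimated at 1500 nM, between 600 nM and 4000 nM.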

Compound 3, half-maximal inhibitory concentration: 11500 nM
For compound 3 the middle estimate is 7.7-fold (0.88 log units) below the measured one; the measured number lies above the stated range.
By their numbers in this assay, from the lowest: compound 2; then compound 1; then compound 3.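

The group on this carbonyl carbon is not interchangeable: going from the six-membered 4-methoxypiperidin-1-yl to the five-membered 3-methoxypyrrolidin-1-yl weakens inhibition, with an 8.1-fold higher number from compound 1 to compound 3 (0.91 log units; beyond the scatter). A small edit to this ring can therefore cost much of the activity, even with the methoxy group kept and the rest of the molecule unchanged. Nothing available explains this loss.

The change alters ring size, the methoxy position and the stereocentre together, so these effects cannot be separated. A 3-methoxypiperidin-1-yl or an unsubstituted pyrrolidin-1-yl group would help to tell them apart.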